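A few compounds are considered here, and "the series" means these few. Any claim that something is new, unique, unknown or untested is made for them only; others in the source may bear on it.

Compound 1 `CCNC1=CC(=O)C=C(C(C)(C)C)C1=O` gives 14000 nM in a functional assay on NCI-H460 cells (Homo sapiens) for cytotoxicity, read by MTT assay, with a stated time of 72 h; on this read-out higher numbers stand for weaker inhibition and lower numbers for stronger inhibition. Compound 2 `CCCCCCCCNC1=CC(=O)C(C(C)(C)C)=CC1=O` gives 65000 nM. Compound 3 `CCCCCCCCNC1=CC(=O)C=C(C[C@]2(C)[C@@H](C)CC[C@]3(C)C(C)=CCC[C@@H]23)C1=O` gives 35000 nM.

Among these three numbers compound 2 holds the highest, that is the weakest inhibition. Its gap to compound 3 falls within the scatter, so no order between the two can be read; its gap to compound 1 lies beyond the scatter, so compound 1 is the stronger inhibitor of that pair. Going by the values given here, no two measured compounds differ in a single place, so no step between them is computed.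

Compound 4 `CNC1=CC(=O)C(C(C)(C)C)=CC1=O` awaits measurement. It differs from compound 2 by hydrogen in place of heptyl on a saturated chain carbon bound to an amine nitrogen. In this assay a modest move to a lower number is expected, a step of a 2.2-fold lower number from compound 2 to compound 4 (0.34 log units; beyond the scatter). Compound 4 is therefore estimated at 30000 nM, within 10000 nM to 90000 nM.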

Compound 4, half-maximal inhibitory concentration: 58000 nM
The estimate for compound 4 lay 1.9-fold (0.29 log units) below the measured number; measured number inside the range.
By their numbers in this assay, from the lowest: compound 1; then compounds 3, 4 and 2 (each within the scatter of the next).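

In this assay hydrogen in place of heptyl on a saturated chain carbon bound to an amine nitrogen gives a 1.1-fold lower number from compound 2 to compound 4 (0.05 log units; within the scatter). Going by these compounds alone, this is the first single change that can be read here, and it shows that on this core the number does not separate from the scatter when heptyl is removed from this place. Nothing measured here offers an explanation for this result. Still open, going by these compounds, is whether a carboxylic acid or a phenyl ring in place of heptyl would move the number beyond the scatter.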